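Removing the cyano from the benzyl group: compound 4

This account rests on a few compounds, and the source may have more. Where it says the series, first, only, none or still open, it means among the compounds named here.

The series shares one core, carried by compound 1 `COc1ccc([C@@H]2CC(=O)c3c(O)cc(OCc4cn(Cc5ccccc5F)nn4)cc3O2)cc1O`, compound 2 `COc1ccc([C@@H]2CC(=O)c3c(O)cc(OCc4cn(Cc5ccc(C)cc5)nn4)cc3O2)cc1O` and compound 3 `COc1ccc([C@@H]2CC(=O)c3c(O)cc(OCc4cn(Cc5ccccc5C#N)nn4)cc3O2)cc1O`, and varies only the substituent on the benzyl group. In a functional assay on RAW264.7 cells (Mus musculus) for inhibition, read by Griess assay, with stated times of 2 h and 24 h (a higher number here means a weaker inhibitor, a lower number a stronger inhibitor), compound 1 gives 7320 nM, compound 2 gives 16800 nM and compound 3 gives 14600 nM. The three numbers lie close together: a 2.3-fold higher number from compound 1 to compound 2 (0.36 log units; beyond the scatter), a 2.0-fold higher number from compound 1 to compound 3 (0.30 log units; within the scatter) and a 1.2-fold lower number from compound 2 to compound 3 (0.06 log units; within the scatter). Compound 3 therefore sits among the others, separated from compound 2 and from compound 1 by steps inside the scatter.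

Compound 4 `COc1ccc([C@@H]2CC(=O)c3c(O)cc(OCc4cn(Cc5ccccc5)nn4)cc3O2)cc1O` is not yet measured. It differs from compound 3 as follows: hydrogen in place of cyano on an aromatic carbon. The step from 2-cyanobenzyl to benzyl thus strips the substituent off altogether. The measured step that bears most directly on it is the exchange of cyano for fluoro on the same aromatic carbon, a 2.0-fold higher number from compound 1 to compound 3 (0.30 log units; within the scatter), which stayed within the scatter; the changes of the whole aryl group, a 2.3-fold higher number from compound 1 to compound 2 (0.36 log units; beyond the scatter) and a 1.2-fold lower number from compound 2 to compound 3 (0.06 log units; within the scatter), were modest at most. Nothing in these numbers points to a large move in either direction in this assay, so the expected step is a 1.2-fold lower number from compound 3 to compound 4 (0.09 log units; within the scatter), with no change beyond the scatter anticipated. Compound 4 is accordingly estimated at 12000 nM, within a range from 5000 nM to 30000 nM.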

Compound 4, half-maximal inhibitory concentration: 11000 nM
The estimate for compound 4 lay 1.1-fold (0.04 log units) above the measured number; low and high end bracket the measured number.
By their numbers in this assay, from the lowest: compounds 1, 4, 3 and 2 (each within the scatter of the next, the first and the last beyond it).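

In this assay, compound 4 gives the series its unsubstituted reference, so each substituent can now be read against hydrogen: the steps are a 1.3-fold lower number from compound 3 to compound 4 (0.12 log units; within the scatter) for loss of cyano, a 1.5-fold lower number from compound 2 to compound 4 (0.18 log units; within the scatter) for loss of methyl and a 1.5-fold higher number from compound 1 to compound 4 (0.18 log units; within the scatter) for loss of fluoro, all within the scatter. None of the three substituents is therefore separated from hydrogen on the aromatic ring of the benzyl group, and the one gap beyond the scatter, a 2.3-fold higher number from compound 1 to compound 2 (0.36 log units; beyond the scatter), lies between two substituted compounds, with compound 4 within the scatter of both. No measurement shown accounts for these small steps or for that single wider gap.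

From the compounds shown here alone, each substituent appears on only one carbon of the aromatic ring, so it remains open whether cyano, fluoro or methyl would read the same on another carbon of that ring. The compounds shown also leave open whether this flat reading extends to an amine or a carboxylic acid on the ring, or to a longer chain in place of the benzyl group.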